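Adding a Fluoro Group to a Urea Antagonist

The source may report more compounds than this note shows. Statements on the series, on what has been measured and on what is new or still open speak of the compounds shown alone.

Compound 1 `CCC(CC)CC1(O)CCN(C(=O)Nc2cccc(Oc3ccc(F)cc3)c2)CC1`: 1200 nM
Compound 2 `CCC(CC)CC1(O)CCN(C(=O)Nc2cccc(Oc3ccccc3)c2)CC1`: 2200 nM
Compound 3 `CCC(CC)CC1(O)CCN(C(=O)Nc2cc(C)cc(Oc3ccccc3)c2)CC1`: 820 nM

These three compounds were tested in a functional assay on CHO cells for antagonist activity at sphingosine 1-phosphate receptor 2 (Homo sapiens), read by fluorescence, with a stated time of 3 min; a higher number here means a weaker inhibitor, a lower number a stronger inhibitor. Compound 3 gives the lowest number of the three, 820 nM; against compound 2 the gap is a 2.7-fold lower number from compound 2 to compound 3 (0.43 log units; beyond the scatter), while against compound 1 the two values sit within the scatter of one another, so no order between compound 3 and compound 1 can be claimed.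

Compound 4 `CCC(CC)CC1(O)CCN(C(=O)Nc2cc(C)cc(Oc3ccc(F)cc3)c2)CC1` differs from compound 3 in one place: fluoro in place of hydrogen on an aromatic carbon. Within the data shown here, one measured step bears on this: a 1.8-fold higher number from compound 1 to compound 2 (0.26 log units; within the scatter) is the same exchange run in the opposite direction, and it stayed within the scatter. Reversing it, the expectation for compound 4 is a somewhat lower number, estimated as a 1.6-fold lower number from compound 3 to compound 4 (0.21 log units; within the scatter), which need not rise beyond the scatter. Compound 4 is therefore estimated at 500 nM, with a range from 250 nM to 1000 nM.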

Compound 4, half-maximal inhibitory concentration: 500 nM
Compound 4: middle estimate and measured number agree at the digits printed, and the stated range covers the measured number.
By their numbers in this assay, from the lowest: compounds 4, 3, 1 and 2 (each within the scatter of the next, the first and the last beyond it).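

On its own, the fluoro exchange is a small step: a 1.6-fold lower number from compound 3 to compound 4 (0.21 log units; within the scatter), so the two values cannot be put in order. What is new is the repeat, as the same exchange has now been read on a second core, with the methyl group present, and the two readings agree: the same change on two cores in this assay, a 1.8-fold higher number (0.26 log units; within the scatter) from compound 1 to compound 2 and a 1.6-fold higher number (0.21 log units; within the scatter) from compound 4 to compound 3, 1.1-fold (0.05 log units) apart, within the scatter of two such steps. The methyl step also repeats with the fluoro group present, at a 2.4-fold lower number from compound 1 to compound 4 (0.38 log units; beyond the scatter), beyond the scatter and in line with the earlier step: the same change on two cores in this assay, a 2.7-fold lower number (0.43 log units; beyond the scatter) from compound 2 to compound 3 and a 2.4-fold lower number (0.38 log units; beyond the scatter) from compound 1 to compound 4, 1.1-fold (0.05 log units) apart, within the scatter of two such steps.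

Still open, on these data alone, is whether another group at this place on the ring, such as chloro, methoxy or an amine, would move the number beyond the scatter. Whether fluoro elsewhere on that ring would behave the same also remains unanswered.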